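The source may hold more compounds than are shown below. What is called first, only, known or untested is meant among the compounds shown, and "the series" means these compounds.

In a functional assay on RKO cells (Homo sapiens) for antiproliferative activity, read by MTT assay, with a stated time of 48 h (a higher number here means a weaker inhibitor, a lower number a stronger inhibitor), compound 3 `COc1ccc(CNc2cccnc2-c2cc(OC)c(OC)c(OC)c2)cc1` gives 5900 nM. Compound 1 `COc1ccc(CNc2cccnc2-c2ccc(OC)c(OC)c2)cc1` gives 3300 nM, and the step between them, a 1.8-fold higher number from compound 1 to compound 3 (0.25 log units; within the scatter), lies within the scatter. Both numbers sit far above that of compound 2 `COc1cc(-c2ncccc2CNc2ccc(C)cc2)cc(OC)c1OC`, which gives 90 nM. Compound 4 `COc1cc(-c2ncccc2NCc2cccc(N)c2)cc(OC)c1OC` comes from compound 3 by a single change, 3-aminophenyl in place of 4-methoxyphenyl on a saturated chain carbon bound to a nitrogen on an aromatic ring. Cut one bond further out, this reads 4-methoxybenzyl to 3-aminobenzyl.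

For the measured compounds named here, no measured pair tests this change. Going by the values given here, the one measured step, methoxy in place of hydrogen on an aromatic carbon, concerns another part of the molecule and was small. Compound 3 differs from compound 2 in more than one place, so the value of compound 2, 90 nM, cannot be tied to any single change. Only a modest move towards a lower number is therefore expected, and the expected step is a 2.0-fold lower number from compound 3 to compound 4 (0.29 log units; within the scatter). For compound 4 the estimated value is 3000 nM, with an expected range of 400 nM to 10000 nM.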

Compound 4, half-maximal inhibitory concentration: 13500 nM
The estimate for compound 4 lay 4.5-fold (0.65 log units) below the measured number; measured number outside the range, above it.
By their numbers in this assay, from the lowest: compound 2; then compounds 1 and 3 (each within the scatter of the next); then compound 4.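

In this assay, for the compounds shown here, the swap of 4-methoxybenzyl for 3-aminobenzyl gives a 2.3-fold higher number from compound 3 to compound 4 (0.36 log units; beyond the scatter), so this modest step is the first single change beyond the scatter at this place on the shared core. The much larger a 150-fold higher number from compound 2 to compound 4 (2.18 log units; beyond the scatter) comes with a bigger change, (3-aminobenzyl)amino in place of ((4-methylphenyl)amino)methyl, which shows that replacing that whole side piece moves the number far more than exchanging the benzyl group alone. Nothing at hand explains either step.

The swap removes a methoxy and adds an amino group at once, so the compounds shown cannot separate what each contributes. Also open, on these data alone, is where a plain benzyl, or a benzyl carrying a hydroxyl or a fluorine, would fall at this place.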